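The source may report more compounds than this note shows. Statements on the series, on what has been measured and on what is new or still open speak of the compounds shown alone.

Compound 1 `CNCc1cc(-c2cccnc2F)n(S(=O)(=O)c2ccsc2)c1` gives 98% in a functional assay on the whole organism (strain Jcl:SD) for inhibition, with Rattus norvegicus as the target, with stated times of 3 min and 3 h, at a dose of 1 mg/kg by the intravenous route; on this read-out higher numbers stand for more inhibition at the one dose given (going by the name of the read-out) and lower numbers for less inhibition.
Compound 2 `CNCc1cc(-c2cccnc2F)n(S(=O)(=O)c2cccs2)c1` gives 96%.
Compound 3 `CNCc1cc(-c2cccnc2F)n(S(=O)(=O)c2cccnc2)c1` gives 96%.

The step of no change at the digits printed from compound 2 to compound 3 (within the scatter) shows no change at the digits printed, and the step of a number 2 percentage points lower from compound 1 to compound 3 (within the scatter) is within the scatter; all three numbers sit high on the scale and level with one another. Compound 4 `CNCc1cc(-c2cccnc2Cl)n(S(=O)(=O)c2cccnc2)c1` differs from compound 3 only in chloro in place of fluoro on an aromatic carbon. Among the compounds with values here, every measured step, including a number 2 percentage points lower from compound 1 to compound 2 (within the scatter), changes the ring on the sulfonyl sulfur and leaves the fluoro untouched, so no measured step bears directly on this change. With the shared core already near the top of the scale, the step of a number 2 percentage points lower from compound 3 to compound 4 (within the scatter) is expected to stay within the scatter. Compound 4 is therefore estimated at 94%, within 84% to 99%.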

Compound 4, a percentage reported as inhibition, in the whole organism at one dose (the size of the read-out at that dose, not a potency): 92%
Estimate against measurement, compound 4: 2 percentage points above, and the stated range covers the measured number.
By their numbers in this assay, from the lowest: compounds 4, 2, 3 and 1 (each within the scatter of the next).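

In this assay, the first change measured at this position gives a number 4 percentage points lower from compound 3 to compound 4 (within the scatter). Chloro therefore serves as well as fluoro on the aromatic carbon next to the ring nitrogen, at least with pyridin-3-yl on the sulfonyl sulfur, so this halogen swap cannot be told apart at the one dose given. No measurement here offers an explanation for this result. On these data alone, whether the two halogens would separate at a lower dose remains open. Also open, as far as these compounds go, is how a methyl, a methoxy or an amine would fare at this position, and whether chloro behaves the same with either thiophene ring on the sulfonyl sulfur.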